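The source may report more compounds than this note shows. Statements on the series, on what has been measured and on what is new or still open speak of the compounds shown alone.

In a functional assay on DU-145 cells (Homo sapiens) for antiproliferative activity, read by MTT assay, with a stated time of 48 h (on this read-out higher numbers stand for weaker inhibition and lower numbers for stronger inhibition), compound 1 (`COc1cc(C(=O)/C=C/c2ccc(OCCCC(=O)NCCCCN(CCCN)CCCCN)cc2)cc(OC)c1OC`) gives 86800 nM. That lies within the scatter of compound 3 (`COc1ccc(/C=C/C(=O)c2cc(OC)c(OC)c(OC)c2)cc1OCCCC(=O)NCCCCN(CCCN)CCCCN`) at 82300 nM, while compound 2 (`COc1ccc(/C=C/C(=O)c2cc(OC)c(OC)c(OC)c2)cc1OCCCC(=O)NCCCNCCCCNCCN`) gives 28500 nM, a clearly lower number. Compound 4 (`COc1cc(C(=O)/C=C/c2ccc(OCCCC(=O)NCCCNCCCCNCCN)cc2)cc(OC)c1OC`) has not been measured yet. Its change from compound 1 is (4-((2-aminoethyl)amino)butyl)amino in place of ((4-aminobutyl)(3-aminopropyl)amino)methyl on a saturated chain carbon, three bonds along the chain from an amide-type nitrogen. The same swap of chains, in the opposite direction and on a related core, appears in one measured step: a 2.9-fold higher number from compound 2 to compound 3 (0.46 log units; beyond the scatter). Among the measured compounds shown here, this modest step is the only guide, and read backwards it points to a lower number, beyond the scatter, of similar size. The expected change is a 2.9-fold lower number from compound 1 to compound 4 (0.46 log units; beyond the scatter). Compound 4 is therefore estimated at 30000 nM, with an expected range from 15000 nM to 60000 nM.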

Compound 4, half-maximal inhibitory concentration: 35400 nM
Estimate against measurement, compound 4: 1.2-fold (0.07 log units) below, and the stated range covers the measured number.
By their numbers in this assay, from the lowest: compounds 2 and 4 (each within the scatter of the next); then compounds 3 and 1 (each within the scatter of the next).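

In this assay the exchange of ((4-aminobutyl)(3-aminopropyl)amino)methyl for (4-((2-aminoethyl)amino)butyl)amino gives a 2.5-fold lower number from compound 1 to compound 4 (0.39 log units; beyond the scatter), so the shift no longer rests on a single core. The change now moves the number the same way on both cores, by a similar amount: the same change on two cores in this assay, a 2.9-fold higher number (0.46 log units; beyond the scatter) from compound 2 to compound 3 and a 2.5-fold higher number (0.39 log units; beyond the scatter) from compound 4 to compound 1, 1.2-fold (0.07 log units) apart, within the scatter of two such steps.

The compounds shown hold only these two chains at this position, so they leave open how a shorter chain ending in one amine, or a chain ending in a carboxylic acid, would read on either core.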